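Acetyl on the nitrogen of compound 3

The compounds below may be only part of what the source reports. "The series", "measured", "known", "first", "only" and "open" are said of these compounds alone.

Values in a functional assay for inhibition, with Homo sapiens as the target; on this read-out higher numbers stand for an effect only at larger amounts of compound and lower numbers for an effect already at smaller amounts
compound 1 `Nc1ccc(C2=NNC(=O)CC2)cc1` gives 46.4 ug/mL
compound 2 `CC(=O)Nc1ccc(C2=NNC(=O)CC2)cc1` gives 1 ug/mL
compound 3 `CC1CC(c2ccc(N)cc2)=NNC1=O` gives 43.8 ug/mL

Compound 3 at 43.8 ug/mL stands level with compound 1 within the scatter, and well apart from compound 2, which shows a far lower number. The next compound is compound 4 `CC(=O)Nc1ccc(C2=NNC(=O)C(C)C2)cc1` and the change to it is acetyl in place of hydrogen on a nitrogen on an aromatic ring with acetyl in place of hydrogen on a nitrogen on an aromatic ring, which also reads amino to acetamido.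

One measured step is this same change. It runs as a 46-fold lower number from compound 1 to compound 2 (1.67 log units; beyond the scatter) and is large, well beyond the scatter. The other measured step, methyl in place of hydrogen on a saturated ring carbon, runs as a 1.1-fold lower number from compound 1 to compound 3 (0.03 log units; within the scatter) and stays within the scatter. Among the compounds with values here, no measurement yet shows the acetyl change with that methyl present, so the transfer rests on a single pair. A step of similar size is expected in this assay toward a lower number, well beyond the scatter. The expected step is an estimate (a 44-fold lower number from compound 3 to compound 4 (1.64 log units; beyond the scatter)). The estimate for compound 4 is 1 ug/mL (expected range 0.3 ug/mL to 4 ug/mL).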

Compound 4, half-maximal effective concentration: 46.4 ug/mL
The estimate for compound 4 lay 46-fold (1.67 log units) below the measured number; measured number outside the range, above it.
By their numbers in this assay, from the lowest: compound 2; then compounds 3, 1 and 4 (each within the scatter of the next).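

In this assay the acetyl on the nitrogen does not carry over from one core to the other: with the methyl on the saturated ring carbon it gives a 1.1-fold higher number from compound 3 to compound 4 (0.03 log units; within the scatter), so the large drop seen without the methyl does not recur: the same change on two cores in this assay, a 46-fold lower number (1.67 log units; beyond the scatter) from compound 1 to compound 2 and a 1.1-fold higher number (0.03 log units; within the scatter) from compound 3 to compound 4, 49-fold (1.69 log units) apart, beyond the scatter of two such steps

Read from the other side, the methyl change has no visible effect on the free amino compounds but gives a 46-fold higher number from compound 2 to compound 4 (1.67 log units; beyond the scatter) once the acetamido group is in place, so the effect of this position depends on the group on the nitrogen: the same change on two cores in this assay, a 1.1-fold lower number (0.03 log units; within the scatter) from compound 1 to compound 3 and a 46-fold higher number (1.67 log units; beyond the scatter) from compound 2 to compound 4, 49-fold (1.69 log units) apart, beyond the scatter of two such steps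

Of the four compounds, only compound 2, with acetamido and hydrogen on that ring carbon, stands apart, and neither change can be read as a fixed increment in this small set.

Still open, as far as these compounds go, is whether the effect of the methyl is specific to it or also appears with an ethyl or a fluorine on the same ring carbon. Equally open, from the compounds shown here alone, is whether a propionyl or a methanesulfonyl on the nitrogen follows the acetyl in either core.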